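The compounds below may be only part of what the source reports. "The series", "measured", "known", "first", "only" and "open" are said of these compounds alone.

Compound 2 `Cc1cn(CCC2(N)OC(=O)C(OCc3ccccc3)=C2OCc2ccccc2)c(=O)[nH]c1=O` was tested in a functional assay on MIA PaCa-2 cells (Homo sapiens) for inhibition, read by MTT assay, with a stated time of 72 h (on this read-out lower numbers stand for stronger inhibition and higher numbers for weaker inhibition), where compound 2 gave only the limit > 100000 nM, not a number. Its nearest measured neighbour, compound 1 `NC1(CCn2ccc(=O)[nH]c2=O)OC(=O)C(OCc2ccccc2)=C1OCc1ccccc1`, differs from it by a methyl in place of hydrogen on an aromatic carbon. In this assay compound 1 likewise returned only the limit > 100000 nM. The step that the two limits leave unreadable from compound 1 to compound 2 is therefore unreadable, since (the limit of > 100000 nM in this assay, at which 2 of the 2 values shown sit). Compound 3 `NC1(CCn2c(=O)[nH]c(=O)[nH]c2=O)OC(=O)C(OCc2ccccc2)=C1OCc1ccccc1` has not yet been measured. It differs from compound 2 by a group of 9 heavy atoms (3 carbon, 3 nitrogen, 3 oxygen; one six-membered aromatic ring with 3 hetero atoms) in place of a group of 9 heavy atoms (5 carbon, 2 nitrogen, 2 oxygen; one six-membered aromatic ring with 2 hetero atoms), on a saturated chain carbon, two bonds along the chain from a saturated ring carbon. Among the measured compounds shown here, no measured step covers a change of this kind, and the only step measured so far, from compound 1 to compound 2, yields no size at all. With both measured neighbours sitting at the limit, compound 3 is expected to sit there as well, so that the step that the limit leaves unreadable from compound 2 to compound 3 is expected to stay within the scatter. Compound 3 is accordingly estimated at 150000 nM in this assay, with a range from 50000 nM to 500000 nM, and most likely it too will be reported only as a limit.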

Compound 3, half-maximal inhibitory concentration: > 100000 nM
Compound 3 ended at the assay's limit (the forecaster's own chance of this, stated with the estimate: 90%); the middle value does not contradict the limit.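

In this assay compound 3 also gave only a limit, so none of the steps among compound 1, compound 2 and compound 3 can be read: the limit of > 100000 nM in this assay, at which 3 of the 3 values shown sit. The compounds shown leave open what number each of the three would take, and whether any group on this saturated chain carbon gives a measurable inhibition.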